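Amino Substitution on Two Chloromethylbenzyl Purine Analogues

The source may hold more compounds than are shown below. What is called first, only, known or untested is meant among the compounds shown, and "the series" means these compounds.

Measured so far in a functional assay on UACC-62 cells (Homo sapiens) for cytotoxicity, read by sulforhodamine B assay, with a stated time of 48 h; a higher number here means a weaker inhibitor of growth, a lower number a stronger inhibitor of growth:
compound 1 `ClCc1ccc(Cn2cnc3c(Cl)ncnc32)cc1` — 1230 nM
compound 2 `Nc1nc(Cl)c2ncn(Cc3ccc(CCl)cc3)c2n1` — 2240 nM
compound 3 `ClCc1ccccc1Cn1cnc2c(Cl)ncnc21` — 3310 nM

Compound 2 arises from compound 1 by amino in place of hydrogen on an aromatic carbon. The step this change made was a 1.8-fold higher number from compound 1 to compound 2 (0.26 log units; within the scatter). Compound 3 has the same atoms as compound 1, joined differently; the difference between the two cores is not broken down here. Compound 3 stands highest of the three numbers, though its distance from compound 2 lies within the scatter. Compound 4 `Nc1nc(Cl)c2ncn(Cc3ccccc3CCl)c2n1`, not yet measured, arises from compound 3 by amino in place of hydrogen on an aromatic carbon, the same change at the same place. The step expected from compound 3 to compound 4 is a 1.7-fold higher number from compound 3 to compound 4 (0.22 log units; within the scatter). This rests on the measured step of a 1.8-fold higher number from compound 1 to compound 2 (0.26 log units; within the scatter), which lay within the scatter. In this assay compound 4 is therefore estimated at 5500 nM, likely between 2500 nM and 13000 nM.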

Compound 4, concentration for 50% growth inhibition: 2240 nM
Beside the measured number, compound 4's estimate is 2.5-fold (0.39 log units) above it; the whole stated range lies above it.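

In this assay, amino in place of hydrogen on an aromatic carbon gave a 1.5-fold lower number from compound 3 to compound 4 (0.17 log units; within the scatter), and this step does not match the one measured on the other core: the same change on two cores in this assay, a 1.8-fold higher number (0.26 log units; within the scatter) from compound 1 to compound 2 and a 1.5-fold lower number (0.17 log units; within the scatter) from compound 3 to compound 4, 2.7-fold (0.43 log units) apart, beyond the scatter of two such steps. The size of the step seen on one core therefore did not carry over to the other, although each step taken alone lies within the scatter. These data do not show what in the two cores sets the steps apart, and two cores cannot say how the change would behave on a further core.

The compounds shown leave open how a methylamino or a hydroxyl group in the same place would behave on these two cores.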